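The source may report more compounds than this note shows. Statements on the series, on what has been measured and on what is new or still open speak of the compounds shown alone.

In a functional assay on LCLC-103H cells (Homo sapiens) for cytotoxicity, with a stated time of 96 h (on this read-out higher numbers stand for weaker inhibition of growth and lower numbers for stronger inhibition of growth), compound 1 `O=C(Oc1cccc2cccnc12)c1cc2c(cc1Cl)SC(N(c1ccc(F)cc1)S(=O)(=O)c1ccc(Br)s1)=NS2(=O)=O` gives 5300 nM, the lower of the two numbers recorded so far, while compound 2 `Cc1cc2c(cc1Cl)SC(N(c1ccc(Cl)cc1)S(=O)(=O)c1ccccc1)=NS2(=O)=O` gives 12400 nM, a gap that lies beyond the usual scatter. Compound 3 `O=C(Oc1cccc2cccnc12)c1cc2c(cc1Cl)SC(N(c1ccc(F)cc1)S(=O)(=O)c1ccc(Cl)cc1)=NS2(=O)=O` has not yet been measured; it differs from compound 1 by 4-chlorophenyl in place of 5-bromothiophen-2-yl on a sulfonyl sulfur. For the measured compounds named here, no measured pair isolates this change, so the expected step to compound 3 in this assay is a 1.1-fold higher number from compound 1 to compound 3 (0.05 log units; within the scatter), roughly a standstill or a shift of no more than modest size in either direction. For compound 3 a value of 6000 nM is expected, ranging from 2500 nM to 14000 nM.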

Compound 3, concentration for 50% growth inhibition: 4600 nM
Compound 3: the middle estimate sits 1.3-fold (0.12 log units) above what was measured; low and high end bracket the measured number.
By their numbers in this assay, from the lowest: compounds 3 and 1 (each within the scatter of the next); then compound 2.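

In this assay, 4-chlorophenyl in place of 5-bromothiophen-2-yl on a sulfonyl sulfur gives a 1.2-fold lower number from compound 1 to compound 3 (0.06 log units; within the scatter) and is the first step shown at this place, so a thiophene and a benzene ring carrying different halogens cannot be told apart here. Nothing given here accounts for this result.

The compounds shown leave open whether this sulfonyl sulfur would tolerate a group without an aromatic ring, such as an amine or a short alkyl chain. They also leave open what a carboxylic acid in place of the chlorine of the 4-chlorophenyl group would do.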